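The source may report more compounds than this note shows. Statements on the series, on what has been measured and on what is new or still open speak of the compounds shown alone.

Three compounds of the series have numbers in an assay on NIH3T3 cells with Urotensin-2 receptor (Homo sapiens) as the target; a lower number here means that less compound is needed, a higher number that more compound is needed for the effect. Compound 1 `Cc1cccc(C(=O)NC(CCN(C)C)c2ccc(Cl)cc2)c1C` gives 3630 nM in this assay. Compound 2 `COc1ccc(NC(=O)OC(CCN(C)C)c2ccc(Cl)cc2)cc1` gives 1660 nM in this assay. Compound 3 `CN(C)CCC(OC(=O)Nc1ccc(C(F)(F)F)cc1)c1ccc(Cl)cc1` differs from compound 2 only at one aromatic carbon, and in this assay compound 3 gives 251 nM. Within the data shown here, compound 3 thus stands lowest of the three: the single change a 6.6-fold lower number from compound 2 to compound 3 (0.82 log units; beyond the scatter) is beyond the scatter, and compound 1 lies further off still, also beyond the scatter.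

Compound 4 `CN(C)CCC(OC(=O)Nc1ccc(-c2ccccc2)cc1)c1ccc(Cl)cc1` has not yet been measured. Its change from compound 3 is phenyl in place of trifluoromethyl on an aromatic carbon. Among the measured compounds shown here, the only measured step at this position is a 6.6-fold lower number from compound 2 to compound 3 (0.82 log units; beyond the scatter), which shows that exchange of the group here can shift the number by a sizeable amount. For the measured compounds named here, no step has a phenyl entering anywhere, so that one step bears only loosely on the present change, and its direction cannot be carried over. The expected step from compound 3 to compound 4 is therefore modest at most, leaning slightly toward a higher number, that is a 1.6-fold higher number from compound 3 to compound 4 (0.20 log units; within the scatter). Compound 4 is estimated at 400 nM in this assay, with a range from 120 nM to 1300 nM.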

Compound 4, half-maximal effective concentration: 269 nM
Compound 4: the middle estimate sits 1.5-fold (0.17 log units) above what was measured, and the stated range covers the measured number.
By their numbers in this assay, from the lowest: compounds 3 and 4 (each within the scatter of the next); then compound 2; then compound 1.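

At this aromatic carbon, para to a large group, phenyl in place of trifluoromethyl gives a 1.1-fold higher number from compound 3 to compound 4 (0.03 log units; within the scatter) in this assay, so the position accepts either a ring-bearing group of 6 heavy atoms or a ring-free group of 4 heavy atoms without a separation between the two numbers. Phenyl in place of methoxy gives a 6.2-fold lower number from compound 2 to compound 4 (0.79 log units; beyond the scatter), which sits alongside a 6.6-fold lower number from compound 2 to compound 3 (0.82 log units; beyond the scatter) and shows that two quite different groups both stand apart from methoxy, so among these three compounds methoxy alone goes with the higher number. No measurement in hand explains why these groups fall where they do.

Open, going by these compounds, is how an amine, a carboxylic acid or a simple fluorine on this same aromatic carbon would compare with trifluoromethyl and phenyl, and whether a ring larger than phenyl would still fit the same picture. Compound 1 differs from the other compounds in more than one place, so the compounds shown cannot say what its amide link alone contributes to the number.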